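Selenium to Sulfur on the Shared Core: Compound 3

The compounds below may be only part of what the source reports. "The series", "measured", "known", "first", "only" and "open" are said of these compounds alone.

Measured so far, in an ADME assay on BEAS-2B cells (Homo sapiens) for cytotoxicity, read by MTT assay, with a stated time of 72 h; a higher number here means a weaker inhibitor of growth, a lower number a stronger inhibitor of growth:
compound 1 `COc1ccc(CNc2nc([SeH])nc3ccccc23)cc1` gives 37400 nM
compound 2 `[SeH]c1nc(NCc2ccccc2)c2ccccc2n1` gives 3540 nM

Compound 1 holds the highest of the two numbers; its nearest neighbour is compound 2, reached through an 11-fold lower number from compound 1 to compound 2 (1.02 log units; beyond the scatter) by hydrogen in place of methoxy on an aromatic carbon. Compound 3 `COc1ccc(CNc2nc(S)nc3ccccc23)cc1` differs from compound 1 by one sulfur atom in place of one selenium atom, on an aromatic carbon: a sulfanyl group between two ring nitrogen atoms. Among the compounds with values here, the only measured step concerns the methoxy group and does not touch this exchange, so no measured step bears on it. Compound 3 is therefore expected to stay near the starting value, with a step of a 1.2-fold higher number from compound 1 to compound 3 (0.08 log units; within the scatter) and an estimate of 45000 nM between 12000 nM and 170000 nM in this assay.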

Compound 3, concentration for 50% growth inhibition: 6130 nM
Beside the measured number, compound 3's estimate is 7.3-fold (0.87 log units) above it; the measured number lies below the stated range.
By their numbers in this assay, from the lowest: compounds 2 and 3 (each within the scatter of the next); then compound 1.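

The exchange of one selenium atom for one sulfur atom on the aromatic carbon between two ring nitrogen atoms gives a 6.1-fold lower number from compound 1 to compound 3 (0.79 log units; beyond the scatter) in this assay. This shows that the number responds to this position as well as to the methoxy group, and that a single atom exchange here is enough to move it beyond the scatter. Nothing available accounts for this step. On these data alone, it remains open whether the same exchange would give a step of similar size on compound 2, which lacks the methoxy group, and what an amine or a hydroxyl group at this position would give.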